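From Ethyl to 3-Methylphenyl on the Amide Carbonyl

This account rests on a few compounds, and the source may have more. Where it says the series, first, only, none or still open, it means among the compounds named here.

Compound 1 `CC(=O)Nc1c(C(O)(C(F)(F)F)C(F)(F)F)ccc2ccccc12` — 87%
Compound 2 `CCC(=O)Nc1c(C(O)(C(F)(F)F)C(F)(F)F)ccc2ccccc12` — 96%
Compound 3 `C/C=C/C(=O)Nc1c(C(O)(C(F)(F)F)C(F)(F)F)ccc2ccccc12` — 96%

Of the compounds shown here, three sharing one core have been measured in a functional assay (Sus scrofa) with sulfonylurea receptors; K-ATP channels (Homo sapiens) as the target; a lower number here means a smaller maximal response, a higher number a larger maximal response. Compound 2 gives 96% and stands level with compound 3 at the digits reported, the two together being the highest of the three numbers; compound 1 gives 87%, the lowest. Every measured step lies within the scatter: a number 9 percentage points higher from compound 1 to compound 2 (within the scatter), a number 9 percentage points higher from compound 1 to compound 3 (within the scatter), and no change at the digits printed from compound 2 to compound 3 (within the scatter). Whatever group has so far been placed on the carbonyl carbon, the largest response has barely moved.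

Compound 4 `Cc1cccc(C(=O)Nc2c(C(O)(C(F)(F)F)C(F)(F)F)ccc3ccccc23)c1` has not yet been measured. It differs from compound 2 in one place: 3-methylphenyl in place of ethyl on a carbonyl carbon. Within the data shown here, the steps so far bear on it only loosely, since none of them brings a ring onto the carbonyl carbon; they show that methyl, ethyl and prop-1-en-1-yl there give responses within the scatter of one another. The account therefore expects no step beyond the scatter, a number 4 percentage points lower from compound 2 to compound 4 (within the scatter), with the wider uncertainty that a change of this size carries. Compound 4 is estimated at 92%, in the range 75% to 105%.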

Compound 4, largest response reached (reported as efficacy), in percent of the reference or control that the assay uses: 97%
The estimate for compound 4 lay 5 percentage points below the measured number; measured number inside the range.
By their numbers in this assay, from the lowest: compounds 1, 2, 3 and 4 (each within the scatter of the next).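

Of the compounds shown, only compound 4 carries a ring on the carbonyl carbon, and in this assay the 3-methylphenyl group gives a number 1 percentage points higher from compound 2 to compound 4 (within the scatter) and also a number 1 percentage points higher from compound 3 to compound 4 (within the scatter) when set against the ethyl and prop-1-en-1-yl groups. Even against methyl the comparison gives a number 10 percentage points higher from compound 1 to compound 4 (within the scatter) and so the maximal response at this position stays within the scatter for the open chains and for this aromatic ring alike. No accompanying measurement bears on why this position accepts the change.

The compounds shown leave open whether the response would also stay within the scatter with an unsubstituted phenyl or a ring carrying a carboxylic acid or an amine on the carbonyl carbon. Going by these compounds, whether a longer chain there would behave as ethyl does also remains open.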